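The source may hold more compounds than are shown below. What is called first, only, known or untested is meant among the compounds shown, and "the series" means these compounds.

Measured in a functional assay (Homo sapiens) for inhibition; on this read-out higher numbers stand for weaker inhibition and lower numbers for stronger inhibition:

Compound 1 `COc1ccc(/C=C/C(=O)c2cccc([N+](=O)[O-])c2)c(OC)c1`: 18000 nM
Compound 2 `COc1ccc(C(=O)/C=C/c2ccc([N+](C)(C)C)cc2)c(OC)c1OC`: 35000 nM
Compound 3 `C=CCOc1ccc(C(=O)/C=C/c2cc(OC)c(CCCCCC)c(OC)c2)cc1`: 15000 nM

Compound 1, at 18000 nM, lies within the usual scatter of both other compounds, so these numbers set no order between it and either of them. Among the measured compounds shown here, the three structures differ in several places at once, and no pair of measured compounds differs in one place only. The data therefore give no direct guide to what a single change does here.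

Compound 4 `COc1ccc(/C=C/C(=O)c2cccc(Br)c2)c(OC)c1` keeps the core of compound 1 and carries bromo in place of nitro on an aromatic carbon. For the measured compounds named here, with no measured step to draw on, the starting point is compound 1 itself. A weak reference point comes from compound 3 at 15000 nM, which has a very different structure yet a value within the scatter of compound 1. No step beyond the scatter is expected, and neither direction is favoured, so the expected change, a 1.2-fold lower number from compound 1 to compound 4 (0.08 log units; within the scatter), is small. For compound 4 the estimated value in this assay is 15000 nM, with an expected range from 6000 nM to 40000 nM.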

Compound 4, half-maximal inhibitory concentration: 37000 nM
Compound 4: the middle estimate sits 2.5-fold (0.39 log units) below what was measured, and the stated range covers the measured number.
By their numbers in this assay, from the lowest: compounds 3, 1, 2 and 4 (each within the scatter of the next, the first and the last beyond it).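

Among the compounds shown here, this is the first pair here that differs in one place only, so a single change can finally be read on its own: in this assay, bromo in place of nitro on this aromatic carbon gives a 2.1-fold higher number from compound 1 to compound 4 (0.31 log units; beyond the scatter). Since a higher number stands for weaker inhibition, the position is not indifferent to what it carries, and nitro gives the stronger inhibition of these two groups, though the step is modest and only just clears the usual scatter. The swap replaces a group of three heavy atoms with two hydrogen-bond acceptors by a single bromine atom with none, but no measurement separates these differences, and nothing available explains the step.

From the compounds shown here alone, it remains open whether an amine, a carboxylic acid or a nitrile on this same aromatic carbon would match nitro, fall nearer to bromo, or lie outside both. A single pair also cannot tell whether the same swap would give a similar step on another carbon of that ring or on a different core, such as that of compound 2 or compound 3.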